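The source may report more compounds than this note shows. Statements on the series, on what has been measured and on what is new or still open speak of the compounds shown alone.

Compounds measured so far:
compound 1, `COc1cc(-c2cc(/C=C/C(=O)c3ccc(N)cc3)[nH]n2)cc(OC)c1OC`, 1600 nM
compound 2, `COc1ccc(-c2cc(/C=C/C(=O)c3ccc(N)cc3)[nH]n2)cc1OC`, 1900 nM
compound 3, `COc1ccc(-c2cc(/C=C/C(=O)c3cc(OC)c(OC)c(OC)c3)[nH]n2)cc1OC`, 1100 nM

In a functional assay on MCF7 cells (Homo sapiens) for inhibition, read by MTT assay, with a stated time of 48 h (a higher number here means a weaker inhibitor, a lower number a stronger inhibitor), compound 1 gives 1600 nM, the second highest of the three numbers. Its nearest neighbour is compound 2 at 1900 nM, and the furthest is compound 3 at 1100 nM; both of these gaps lie within the scatter, so the three compounds cannot be set in order on these numbers.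

Compound 4, `COc1ccc(C(=O)/C=C/c2cc(-c3cc(OC)c(OC)c(OC)c3)n[nH]2)cc1OC`, is not yet measured. It differs from compound 1 in one place: 3,4-dimethoxyphenyl in place of 4-aminophenyl on a carbonyl carbon.

For the measured compounds named here, only one step has been measured, a 1.2-fold higher number from compound 1 to compound 2 (0.07 log units; within the scatter), and it concerns a methoxy on the other aromatic ring, not the ring on the carbonyl carbon, so it does not bear directly on the change to compound 4. Going by the values given here, compound 2 and compound 3 differ in the ring on the carbonyl carbon, but no step is given for them. Compound 2 gives 1900 nM, and compound 3 gives 1100 nM; the two values sit close to each other. Nothing measured suggests a large effect of the ring on the carbonyl carbon.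

The step from compound 1 to compound 4 is therefore expected to be small, a 1.2-fold lower number from compound 1 to compound 4 (0.09 log units; within the scatter), without a clear direction beyond the scatter. Compound 4 is estimated at 1300 nM, in the range 600 nM to 2800 nM.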

Compound 4, half-maximal inhibitory concentration: 510 nM
The estimate for compound 4 lay 2.5-fold (0.41 log units) above the measured number; measured number outside the range, below it.
By their numbers in this assay, from the lowest: compound 4; then compounds 3, 1 and 2 (each within the scatter of the next).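

In this assay the change of 3,4-dimethoxyphenyl in place of 4-aminophenyl on a carbonyl carbon gives a 3.1-fold lower number from compound 1 to compound 4 (0.50 log units; beyond the scatter) and is the first step among these compounds to lie beyond the scatter, while the only earlier step, a 1.2-fold higher number from compound 1 to compound 2 (0.07 log units; within the scatter) for hydrogen in place of methoxy on an aromatic carbon, stayed within it. The group on the carbonyl carbon is therefore a place where the number does move in this assay, although the step is modest and rests on this one pair. The entering group differs from the leaving one in heavy atoms, hydrogen-bond donors and hydrogen-bond acceptors alike, and no measurement here speaks to the reason for the step.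

On these data alone, what stays open is whether the step follows from the two methoxy groups entering or from the amine leaving, and a plain phenyl or a 4-methoxyphenyl on the carbonyl carbon would separate the two. As far as these compounds go, it is also open whether an acetamide on that ring, or a hydroxyl in place of one methoxy, would keep the lower number.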